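This account rests on a few compounds, and the source may have more. Where it says the series, first, only, none or still open, it means among the compounds named here.

In a functional assay on U-251 cells (Homo sapiens) for cytotoxicity (a lower number here means a stronger inhibitor of growth, a higher number a weaker inhibitor of growth), three compounds with a shared core differ only in one group on an aromatic ring. The bromo compound 1 (`COc1ccc(C2=C(c3ccc(SC)cc3)CC3CCCN3C2=O)cc1Br`) gives 800 nM, the methyl compound 2 (`COc1ccc(C2=C(c3ccc(SC)cc3)CC3CCCN3C2=O)cc1C`) gives 90 nM, and the methoxy compound 3 (`COc1ccc(C2=C(c3ccc(SC)cc3)CC3CCCN3C2=O)cc1OC`) gives 300 nM, which puts compound 3 in the middle of the three.

Compound 4 (`COc1ccc(C2=C(c3ccc(SC)cc3)CC3CCCN3C2=O)cc1`) is the next case, with hydrogen in place of methoxy on an aromatic carbon. Among the measured compounds shown here, no measured step places hydrogen here, so the evidence is only indirect. Swapping groups at this carbon gave an 8.9-fold lower number from compound 1 to compound 2 (0.95 log units; beyond the scatter), a 2.7-fold lower number from compound 1 to compound 3 (0.43 log units; beyond the scatter) and a 3.3-fold higher number from compound 2 to compound 3 (0.52 log units; beyond the scatter). These modest steps show that the number responds to this position, but they do not show which way hydrogen will move it. The best guess therefore stays close to compound 3, with a slight lean towards a higher number. The estimated change is a 1.3-fold higher number from compound 3 to compound 4 (0.12 log units; within the scatter), although a step as large as the measured ones is possible in either direction. For compound 4 the expected value is 400 nM, with an estimated range from 100 nM to 1500 nM.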

Compound 4, concentration for 50% growth inhibition: 2000 nM
Compound 4: middle estimate off by 5.0-fold (0.70 log units), on the low side, outside the stated range (above it).
By their numbers in this assay, from the lowest: compound 2; then compound 3; then compound 1; then compound 4.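

In this assay, the step to hydrogen runs the same way from all three substituted compounds: a 6.7-fold higher number from compound 3 to compound 4 (0.82 log units; beyond the scatter), a 22-fold higher number from compound 2 to compound 4 (1.35 log units; beyond the scatter) and a 2.5-fold higher number from compound 1 to compound 4 (0.40 log units; beyond the scatter). Among the compounds shown here, the earlier compounds showed only that the choice of group at this carbon matters, whereas compound 4 shows that each of these three groups, ortho to a methoxy group, gives stronger growth inhibition than hydrogen, even bromo, which has the highest number of the three. No measurement available here accounts for this difference. 

As far as these compounds go, what an ethyl group, a fluoro group or an amine would do at this carbon remains open. So does whether any group could give a lower number than methyl, or whether the same order would hold in other cell lines.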